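Swapping one core chlorine in two benzyl purine pairs

The compounds below may be only part of what the source reports. "The series", "measured", "known", "first", "only" and "open" are said of these compounds alone.

Three compounds share a purine-like core carrying a chloromethyl-substituted benzyl group and were compared in a functional assay on T47D cells (Homo sapiens) for cytotoxicity, read by sulforhodamine B assay, with a stated time of 48 h; on this read-out higher numbers stand for weaker inhibition of growth and lower numbers for stronger inhibition of growth. Compound 1 `ClCc1cccc(Cn2cnc3ncnc(Cl)c32)c1` gives 500 nM in this assay. Compound 3 `ClCc1cccc(Cn2cnc3nc(Cl)nc(Cl)c32)c1` gives 610 nM, and the step of a 1.2-fold lower number from compound 3 to compound 1 (0.09 log units; within the scatter) comes from the change (hydrogen in place of chloro on an aromatic carbon). Compound 2 `ClCc1ccc(Cn2cnc3nc(Cl)nc(Cl)c32)cc1` gives 46800 nM in this assay, the highest of the three numbers and far from the other two. The difference between the core of compound 2 and the core of compound 3 is not broken down here.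

Compound 4 `ClCc1ccc(Cn2cnc3ncnc(Cl)c32)cc1` has not yet been tested in this assay. It differs from compound 2 by hydrogen in place of chloro on an aromatic carbon, the same change that was made from compound 3 to compound 1, at the same place. For the measured compounds named here, because that change gave a 1.2-fold lower number from compound 3 to compound 1 (0.09 log units; within the scatter), a step that stayed within the scatter, the corresponding step for compound 4 is expected to be small as well, and the estimate rests on the single measured pair only. Compound 4 is therefore estimated to stay close to compound 2, with an expected step of a 1.2-fold lower number from compound 2 to compound 4 (0.07 log units; within the scatter). Compound 4 is expected to give about 40000 nM, with a range from 12000 nM to 130000 nM in this assay.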

Compound 4, concentration for total growth inhibition: 2880 nM
Estimate against measurement, compound 4: 14-fold (1.14 log units) above, outside the stated range (below it).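

On the second core the change was not small: in this assay, hydrogen in place of chloro on the aromatic carbon between two ring nitrogen atoms gave a 16-fold lower number from compound 2 to compound 4 (1.21 log units; beyond the scatter). The size of this step therefore did not carry over from one pair to the other, and the two pairs, which differ in where the chloromethyl group sits on the benzyl ring, gave clearly different results for the same change: the same change on two cores in this assay, a 1.2-fold lower number (0.09 log units; within the scatter) from compound 3 to compound 1 and a 16-fold lower number (1.21 log units; beyond the scatter) from compound 2 to compound 4, 13-fold (1.12 log units) apart, beyond the scatter of two such steps. For the compounds shown here, this shows that, in this series, a step measured on one core cannot be taken as a guide to the same step on the other, but it rests on only two pairs in a single cell assay, and it does not show what underlies the difference or how the change would behave on any further core.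

The compounds shown leave open how an amine or a methyl group on that same ring carbon would read in this assay on either core. They also leave open how the size of this step would change if a hydroxymethyl group or a longer chain stood in place of the chloromethyl group.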